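Replacing the aryl group of compound 2

The compounds below may be only part of what the source reports. "The series", "measured", "known", "first", "only" and "open" are said of these compounds alone.

- compound 1 (`COc1cc(C=C2C(=O)N(c3ccc(Cl)cc3)N(c3ccc(Cl)cc3)C2=O)cc(OC)c1OC`): 17300 nM
- compound 2 (`COc1cccc(C=C2C(=O)N(c3ccc(Cl)cc3)N(c3ccc(Cl)cc3)C2=O)c1O`): 24300 nM

In a functional assay on MGC-803 cells (Homo sapiens) for cytotoxicity, read by MTT assay, with a stated time of 72 h (a lower number here means a stronger inhibitor, a higher number a weaker inhibitor), compound 2 stands at 24300 nM and so lies within the usual scatter of compound 1 (17300 nM). Compound 3 (`O=C1C(=Cc2ccc(Cl)cc2Cl)C(=O)N(c2ccc(Cl)cc2)N1c1ccc(Cl)cc1`) carries 2,4-dichlorophenyl in place of 2-hydroxy-3-methoxyphenyl on a double-bonded chain carbon bound to a double-bonded ring carbon. Among the compounds with values here, no measured step shows what a change in this place does in this assay and the expectation rests only on the two values at hand. Neither direction is favoured, and no step beyond the scatter is expected. The estimated change is a 1.2-fold lower number from compound 2 to compound 3 (0.08 log units; within the scatter) and it stays within that scatter. For compound 3 the expected value is 20000 nM (estimated range 7000 nM to 50000 nM).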

Compound 3, half-maximal inhibitory concentration: > 128000 nM
Compound 3: a limit, no number; the forecaster's own chance of this, stated with the estimate: 10%; at least 6.4-fold (0.80 log units) between middle value and limit.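

In this assay compound 3 gives > 128000 nM, which is a limit of the assay and not a number: the limit of > 128000 nM in this assay, at which 1 of the 3 values shown sits.
Within the data shown here, putting 2,4-dichlorophenyl in place of 2-hydroxy-3-methoxyphenyl on a double-bonded chain carbon bound to a double-bonded ring carbon gives an at least 5.2-fold higher number from compound 2 to compound 3 (0.72 log units; beyond the scatter) and so marks the first step beyond the scatter. Compound 1 and compound 2 lie within the scatter of each other, so only compound 3 shows that this position does not accept every aryl group equally.

The compounds shown leave open whether the step follows from the loss of the hydroxy and methoxy groups or from the arrival of the two chlorine atoms, as both changes occur together. They also leave open how an aryl group carrying an amine or a carboxylic acid would behave at this position.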